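The source may report more compounds than this note shows. Statements on the series, on what has been measured and on what is new or still open speak of the compounds shown alone.

In a functional assay on L78 cells (Homo sapiens) for antiproliferative activity, read by MTT assay, with a stated time of 72 h (a lower number here means a stronger inhibitor, a higher number a weaker inhibitor), compound 1 `O=C1C=C(N2CCN(c3ccccc3Cl)CC2)C(=O)c2ccccc21` gives 28800 nM, while compound 2 `O=C1C=C(N2CCC(c3ccccc3)CC2)C(=O)c2c(O)cccc21` gives 13400 nM, the lower of the two numbers, with a gap beyond the usual scatter. Compound 3 `O=C1C=C(N2CCC(c3ccc(Cl)cc3)CC2)C(=O)c2c(O)cccc21` differs from compound 2 in one place: chloro in place of hydrogen on an aromatic carbon. This puts chloro in place of hydrogen on an aromatic carbon, turning phenyl into 4-chlorophenyl. For the measured compounds named here, no measured pair shows this change, so only a modest move towards a lower number is expected in this assay, perhaps not beyond the scatter. The expected size is a 1.4-fold lower number from compound 2 to compound 3 (0.15 log units; within the scatter). Compound 3 is estimated at 9500 nM, within a range of 3500 nM to 24000 nM.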

Compound 3, half-maximal inhibitory concentration: 40600 nM
Compound 3: middle estimate off by 4.3-fold (0.63 log units), on the low side; the whole stated range lies below it.
By their numbers in this assay, from the lowest: compound 2; then compounds 1 and 3 (each within the scatter of the next).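

Turning phenyl into 4-chlorophenyl, with the chloro para to a large group, gives a 3.0-fold higher number from compound 2 to compound 3 (0.48 log units; beyond the scatter) in this assay, so at this position the change goes with weaker antiproliferative activity. This reading rests on a single pair of compounds. Nothing shown offers an explanation for the shift.

On these data alone, whether a smaller fluoro, a methoxy or an amine on the same aromatic carbon would also raise the number remains open. So does whether chloro would behave the same way elsewhere on that ring.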